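A hydroxyethyl piperidine replaces the hydroxymethyl one

A few compounds are considered here, and "the series" means these few. Any claim that something is new, unique, unknown or untested is made for them only; others in the source may bear on it.

In a functional assay on SH-SY5Y cells (Homo sapiens) for antiproliferative activity, read by MTT assay, with a stated time of 72 h (a higher number here means a weaker inhibitor, a lower number a stronger inhibitor), compound 1 `CCN(CC)CCCOc1cc2ncnc(Nc3ccc(C#N)cc3)c2cc1OC` reaches only a limit, > 100000 nM. Among the measured compounds shown here, compound 2 `COc1cc2c(Nc3ccc(C#N)cc3)ncnc2cc1OCCCN1CCC(CO)CC1` gives 21600 nM, the only actual number so far. For the measured compounds named here, one measured step bears on what follows: an at least 4.6-fold lower number from compound 1 to compound 2 (0.66 log units; beyond the scatter), with 4-(hydroxymethyl)piperidin-1-yl in place of diethylamino. Compound 3 `COc1cc2c(Nc3ccc(C#N)cc3)ncnc2cc1OCCCN1CCCCC1CCO` carries 2-(2-hydroxyethyl)piperidin-1-yl instead, on the same saturated chain carbon: 2-(2-hydroxyethyl)piperidin-1-yl in place of 4-(hydroxymethyl)piperidin-1-yl on a saturated chain carbon, three bonds along the chain from an oxygen on an aromatic ring. That earlier step starts from a limit and replaced a different group, so no step beyond the scatter is expected in this assay. The estimated change is a 1.1-fold lower number from compound 2 to compound 3 (0.03 log units; within the scatter). For compound 3 the expected value is 20000 nM, with an estimated range of 7000 nM to 60000 nM.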

Compound 3, half-maximal inhibitory concentration: > 100000 nM
Compound 3: a limit, no number (the forecaster's own chance of this, stated with the estimate: 15%); middle value at least 5.0-fold (0.69 log units) from the limit.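

In this assay, a piperidine bearing a hydroxyl side chain does not by itself keep the activity of compound 2: on the same saturated chain carbon, 2-(2-hydroxyethyl)piperidin-1-yl gives an at least 4.6-fold higher number from compound 2 to compound 3 (0.66 log units; beyond the scatter). Among the compounds shown, only 4-(hydroxymethyl)piperidin-1-yl gives an actual number at this position. The value of compound 3 is a limit, and the step from compound 1 to compound 3 cannot be read: the limit of > 100000 nM in this assay, at which 2 of the 3 values shown sit.

This one change alters both the length of the side chain and its place on the piperidine, and the two effects remain unseparated. From the compounds shown here alone, whether 4-(2-hydroxyethyl)piperidin-1-yl or 2-(hydroxymethyl)piperidin-1-yl would give a number in this assay stays open.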